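Methoxy for Hydroxyethyl: Expected Liver Microsome Stability

This account rests on a few compounds, and the source may have more. Where it says the series, first, only, none or still open, it means among the compounds named here.

Measured so far:
compound 1 `O=C(CCO)N[C@@H](CO)C(=O)O`: 87%
compound 2 `CC(C)C(=O)N[C@@H](CO)C(=O)O`: 49%

Of the compounds shown here, two have been measured in an ADME assay on microsomes from liver (Mus musculus) for metabolic stability, with a stated time of 30 min; on this read-out lower numbers stand for a less stable compound and higher numbers for a more stable compound. Compound 1 gives 87% in this assay and stands highest of the two numbers. Compound 2 carries isopropyl in place of 2-hydroxyethyl on a carbonyl carbon and gives 49% in this assay; the step of a number 38 percentage points lower from compound 1 to compound 2 (beyond the scatter) lies beyond the scatter and is large.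

Compound 3 `COC(=O)N[C@@H](CO)C(=O)O` has not yet been measured in this assay. It differs from compound 1 as follows: methoxy in place of 2-hydroxyethyl on a carbonyl carbon. For the measured compounds named here, the one measured step that bears on this change is a number 38 percentage points lower from compound 1 to compound 2 (beyond the scatter), in which the same 2-hydroxyethyl left the same carbonyl carbon. Going by the values given here, both changes remove the one hydrogen-bond donor of that group, but methoxy is a smaller group than isopropyl and keeps one hydrogen-bond acceptor, so a drop is expected, though smaller than the one seen for compound 2. Compound 3 is therefore estimated at 70% in this assay, between 50% and 90%, which means an expected step of a number 17 percentage points lower from compound 1 to compound 3 (beyond the scatter).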

Compound 3, percent of the compound remaining: 27%
Compound 3: the middle estimate sits 43 percentage points above what was measured; measured number outside the range, below it.
By their numbers in this assay, from the lowest: compound 3; then compound 2; then compound 1.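

In this assay, methoxy in place of 2-hydroxyethyl on a carbonyl carbon brings a number 60 percentage points lower from compound 1 to compound 3 (beyond the scatter) and leaves compound 3 as the lowest of the three compounds, so a second replacement at this place has now lowered the number. Methoxy in place of isopropyl on the same carbonyl carbon gives a number 22 percentage points lower from compound 2 to compound 3 (beyond the scatter) and so shows that the two replacing groups are not equivalent here, with methoxy giving the lower number of the two. Methoxy has the same count of hydrogen-bond acceptors as 2-hydroxyethyl and lacks only its hydrogen-bond donor, so matching that acceptor count did not keep the number near that of compound 1.

The three compounds leave open whether the high number of compound 1 depends on the hydroxyl itself or on the two-carbon chain that carries it, a question that 2-methoxyethyl, 2-aminoethyl or a plain ethyl group at this place could address. Nothing available here accounts for the order of the three numbers.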